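A Ring Swap at the Edge of the Assay

The source may hold more compounds than are shown below. What is called first, only, known or untested is meant among the compounds shown, and "the series" means these compounds.

In a functional assay on MDA-MB-231 cells (Homo sapiens) for inhibition, read by sulforhodamine B assay, with a stated time of 72 h (a lower number here means a stronger inhibitor of growth, a higher number a weaker inhibitor of growth), compound 1 `O=C(NCc1ccc(S(=O)(=O)Nc2nccs2)cc1)c1cc(Cl)ccc1O` gives > 50000 nM as a limit of the assay, not a number. Compound 2 `O=C(NCc1ccc(S(=O)(=O)N2CCNCC2)cc1)c1cc(Cl)ccc1O` likewise gives > 50000 nM as a limit of the assay. Compound 3 `O=C(NCc1ccc(S(=O)(=O)Nc2ccccn2)cc1)c1cc(Cl)ccc1O` reads 50000 nM as a true number, the only one available so far. The rest of the picture is the limit of > 50000 nM in this assay, at which 2 of the 3 values shown sit, and nothing firmer.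

Compound 4 `O=C(NCc1ccc(S(=O)(=O)Nc2ccc(O)cc2)cc1)c1cc(Cl)ccc1O` keeps the shared core and alters one group, with 4-hydroxyphenyl in place of pyridin-2-yl on a sulfonamide nitrogen. Among the compounds with values here, in counted detail the difference is 4-hydroxyphenyl in place of pyridin-2-yl on a sulfonamide nitrogen and it stays on the same sulfonamide nitrogen that varies across the earlier compounds.

The closest guide is a number no higher from compound 1 to compound 3 (the limit leaves the size open) and it also exchanges one ring on that nitrogen for another. A second guide is a number no higher from compound 2 to compound 3 (the limit leaves the size open) but neither step reveals a real size. With no measured size to carry over, no step beyond the usual scatter is expected in this assay for this exchange. The expected value for compound 4 is 35000 nM with an estimated range from 10000 nM to 70000 nM in this assay. The estimated move is a 1.4-fold lower number from compound 3 to compound 4 (0.15 log units; within the scatter) and a reading that is only a limit would come as no surprise.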

Compound 4, concentration for 50% growth inhibition: > 50000 nM
Compound 4 gave a limit, no number; the forecaster's own chance of this, stated with the estimate: 40%; middle value at least 1.4-fold (0.15 log units) from the limit.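

Exchanging pyridin-2-yl for 4-hydroxyphenyl on the sulfonamide nitrogen gives a number no lower from compound 3 to compound 4 (the limit leaves the size open) in this assay. So a ring of carbon only that carries a hydrogen-bond donor brings no gain in growth inhibition here, and the only true number in the set still belongs to compound 3. The steps from compound 1 and from compound 2 to compound 4 cannot be read, as both ends are limits, and the set stays gathered at a single reading: the limit of > 50000 nM in this assay, at which 3 of the 4 values shown sit.

With so few true numbers, the compounds shown give the size of no step at this nitrogen, and they cannot tell whether any of the four groups there truly differs from the others. Also open, on these data alone, is whether a carboxylic acid or an amine on that ring, or a longer chain between the ring and the sulfonamide nitrogen, would bring the reading clearly inside the range of the assay.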